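Extending the Aryl Methyl to Butyl in Compound 4

The compounds below may be only part of what the source reports. "The series", "measured", "known", "first", "only" and "open" are said of these compounds alone.

Compound 1 `CC1CC/C(=N\Nc2ccccc2F)c2ncc(C(=O)O)c(=O)n21` gives in a functional assay on the whole organism for inhibition, with Rattus norvegicus as the target (a lower number here means that less compound is needed, a higher number that more compound is needed for the effect), only a limit, > 1000 umol/kg. Compound 2 `CC1CC/C(=N\Nc2ccccc2Br)c2ncc(C(=O)O)c(=O)n21` gives, again a limit, > 320 umol/kg. Compound 3 `Cc1ccc(N/N=C2\CCC(C)n3c2ncc(C(=O)O)c3=O)cc1` gives, also a limit, > 1000 umol/kg.

Compound 3 thus stands among limits alone: the limit of > 1000 umol/kg in this assay, at which 2 of the 3 values shown sit, holds its value together with one other, and the limit of > 320 umol/kg in this assay, at which 1 of the 3 values shown sits, holds the remaining one. The steps a step that the two limits leave unreadable from compound 1 to compound 2, a step that the two limits leave unreadable from compound 1 to compound 3 and a step that the two limits leave unreadable from compound 2 to compound 3 are all unreadable, so none of them has a size. Compound 4 `CCCCc1ccc(N/N=C2\CCC(C)n3c2ncc(C(=O)O)c3=O)cc1` differs from compound 3 by propyl in place of hydrogen on a saturated chain carbon bound to an aromatic carbon. For the measured compounds named here, no measured step bears on this change, and no direction can be read for this assay. Compound 4 is therefore expected to give about 1500 umol/kg, in a range from 300 umol/kg to 6000 umol/kg, an estimated step that the limit leaves unreadable from compound 3 to compound 4, most likely again reported as a limit.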

Compound 4, dose for 50% inhibition: 100 umol/kg
Beside the measured number, compound 4's estimate is 15-fold (1.18 log units) above it, and the stated range ends above it.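

Extending methyl to butyl on a saturated chain carbon bound to an aromatic carbon gives an at least 10-fold lower number from compound 3 to compound 4 (1.00 log units; beyond the scatter) in this assay. For the compounds shown here, the earlier compounds gave only limits, so their steps cannot be read, and this is the first sign that the dose needed can respond to a change in the structure. Nothing shown gives a reason for this step.

From the compounds shown here alone, it remains open whether a shorter ethyl chain would already lower the number, or a longer hexyl chain would lower it further. Going by these compounds, how a chain ending in an amine would read is also open.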